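Chloro to Nitro on the Shared Quinoxaline-Free Core

This account rests on a few compounds, and the source may have more. Where it says the series, first, only, none or still open, it means among the compounds named here.

The measured compounds:
compound 1, `CCCCCCCCc1nc2ccc(C)cc2nc1CCCCCCCC(=O)O`, 12.5%
compound 2, `CCCCCCCCc1nc2ccc(Cl)cc2nc1CCCCCCCC(=O)O`, 26.7%
compound 3, `CCCCCCCCC1=NC(=O)CC(=O)N=C1CCCCCCCC(=O)O`, 1.74%

In a functional assay on the whole organism for inhibition, with Rattus norvegicus as the target, read by paw edema, with a stated time of 3 h, at a dose of 100 mg/kg by the oral route (on this read-out lower numbers stand for less inhibition and higher numbers for more inhibition at the one dose given (going by the name of the read-out)), compound 2 stands highest of the three numbers. Among the compounds with values here, its nearest neighbour is compound 1, and the one change between them, chloro in place of methyl on an aromatic carbon, gave a number 14.2 percentage points higher from compound 1 to compound 2 (beyond the scatter). Within the data shown here, compound 3, whose core differs from the other two, gives the lowest number, and no single step connects it to compound 2.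

The unmeasured compound 4, `CCCCCCCCc1nc2ccc([N+](=O)[O-])cc2nc1CCCCCCCC(=O)O`, differs from compound 2 only by nitro in place of chloro on an aromatic carbon. Among the measured compounds shown here, the one step that bears on this position, from compound 1 to compound 2, was modest and upward, but it concerned a different pair of groups, so it says nothing direct about a nitro group here. For the measured compounds named here, with no measured step for nitro, the account expects compound 4 to stay near compound 2, with a step of a number 3.3 percentage points higher from compound 2 to compound 4 (within the scatter) that may not exceed the scatter. The estimate for compound 4 is 30%, within 10% to 50%.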

Compound 4, a percentage reported as inhibition, in the whole organism at one dose (the size of the read-out at that dose, not a potency): 39.6%
Beside the measured number, compound 4's estimate is 9.6 percentage points below it; the measured number falls inside the stated range.
By their numbers in this assay, from the lowest: compound 3; then compound 1; then compound 2; then compound 4.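

Nitro in place of chloro on this aromatic carbon gave a number 12.9 percentage points higher from compound 2 to compound 4 (beyond the scatter) in this assay, so the number at this position had not levelled off at chloro. Nitro in place of methyl gave a number 27.1 percentage points higher from compound 1 to compound 4 (beyond the scatter), which is the widest step among the compounds that share this core, and the three groups at this one position now rank methyl, then chloro, then nitro, from lowest to highest. Nothing measured here accounts for that order.

On these data alone, what stays open is where other groups would fall in this order, such as an amine, a methoxy group or a single fluorine atom on the same carbon. Also open, as far as these compounds go, is whether the order would hold with a shorter chain in place of the octyl chain of the shared core.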